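A few compounds are considered here, and "the series" means these few. Any claim that something is new, unique, unknown or untested is made for them only; others in the source may bear on it.

In a functional assay on SH-SY5Y cells (Homo sapiens) for cytotoxicity, read by MTT assay, with a stated time of 72 h (on this read-out lower numbers stand for stronger inhibition and higher numbers for weaker inhibition), compound 3 `O=C1c2c[n+]([O-])c3ccccc3c2C(=O)c2c1c1ccccc1n2CCCCN1CCCCC1` gives 230 nM, and compound 1 `O=C1c2c[n+]([O-])c3ccccc3c2C(=O)c2c1c1ccccc1n2CCCCn1ccnc1` gives 130 nM. These two numbers lie within the scatter of each other, and no other exact number is available for comparison. Compound 2 `O=C1c2c[n+]([O-])c3ccccc3c2C(=O)c2c1c1ccccc1n2Cc1cn(C[C@H](O)CO)nn1` is reported only as a limit, > 1000 nM. The steps that involve it, an at least 7.6-fold higher number from compound 1 to compound 2 (0.88 log units; beyond the scatter) and an at least 4.3-fold lower number from compound 2 to compound 3 (0.63 log units; beyond the scatter), replace the whole side chain and therefore say little about a change at the end of the chain.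

Compound 4 `CN(C)CCCCn1c2c(c3ccccc31)C(=O)c1c[n+]([O-])c3ccccc3c1C2=O` keeps the core and chain of compound 3 and differs at one place: dimethylamino in place of piperidin-1-yl on a saturated chain carbon, four bonds along the chain from an aromatic nitrogen. It carries dimethylamino in place of piperidin-1-yl on a saturated chain carbon, four bonds along the chain from an aromatic nitrogen. Going by the values given here, the one measured exchange at this same place is a 1.8-fold higher number from compound 1 to compound 3 (0.25 log units; within the scatter). On that single precedent, the change in this assay is expected to produce no step beyond the scatter, in either direction. The expected step is a 1.2-fold lower number from compound 3 to compound 4 (0.06 log units; within the scatter). Compound 4 is expected to give about 200 nM, with an estimated range from 80 nM to 500 nM.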

Compound 4, half-maximal inhibitory concentration: 250 nM
Compound 4: the middle estimate sits 1.3-fold (0.10 log units) below what was measured; the measured number falls inside the stated range.
By their numbers in this assay, from the lowest: compounds 1, 3 and 4 (each within the scatter of the next). At a limit, above all of these: compound 2.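

In this assay, the second exchange at this place, on a saturated chain carbon, four bonds along the chain from an aromatic nitrogen, gives a 1.1-fold higher number from compound 3 to compound 4 (0.04 log units; within the scatter), and the comparison with the imidazole end gives a 1.9-fold higher number from compound 1 to compound 4 (0.28 log units; within the scatter). Dimethylamino, which has no ring, thus stands within the scatter of both piperidin-1-yl and 1H-imidazol-1-yl, so among these three compounds a ring at the end of the chain is not needed for a number of this size, and the smaller group with fewer heavy atoms makes no readable difference. The remaining step, an at least 4.0-fold lower number from compound 2 to compound 4 (0.60 log units; beyond the scatter), replaces the whole side chain and therefore says little about the end group alone, and its size is only a bound, as compound 2 is known only as a limit: the limit of > 1000 nM in this assay, at which 1 of the 4 values shown sits.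

The compounds shown leave open whether a carboxylic acid, an amide or a hydroxyl at the end of the chain would stay within the same scatter as the amines and the imidazole. They also leave open whether a shorter or a longer chain carrying dimethylamino would change the number in this assay.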